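This account rests on a few compounds, and the source may have more. Where it says the series, first, only, none or still open, it means among the compounds named here.

Of the compounds shown here, three that share one core have been tested in a functional assay on the whole organism with Rattus norvegicus as the target; a lower number here means that less compound is needed, a higher number that more compound is needed for the effect. There, compound 3 (`Cc1cc(S(C)(=O)=O)c(NC(=O)N(Cc2ccc(Oc3ccc(F)cc3)cc2)C2CCCCCC2)c(S(C)(=O)=O)n1`) gives 0.068 mg/kg. Going by the values given here, compound 1 (`CSc1nc(C)nc(SC)c1NC(=O)N(Cc1ccc(Oc2ccc(F)cc2)cc1)C1CCCCCC1`) gives 0.069 mg/kg, which lies within the scatter of compound 3, and these are the only two numbers available. Compound 2 (`Cc1cc(Cl)c(NC(=O)N(Cc2ccc(Oc3ccc(F)cc3)cc2)C2CCCCCC2)c(Cl)n1`) gives > 0.1 mg/kg, which is a limit and not a number.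

Compound 4 (`Cc1cc(S(C)(=O)=O)c(NC(=O)N(Cc2ccc(Oc3ccc(F)cc3)cc2)C2CCCCCC2)c(Cl)n1`) differs from compound 3 by one change, chloro in place of methylsulfonyl on an aromatic carbon, next to the ring nitrogen. The methylsulfonyl group at the other place stays. Compound 2 carries chloro at both of these places, so compound 4 stands structurally between compound 3 and compound 2.

Among the compounds with values here, the one measured step that bears on this is an at least 1.4-fold higher number from compound 1 to compound 2 (0.16 log units; that floor lies within the scatter), and it gives only a floor. A small move toward a higher number in this assay is therefore expected, possibly no larger than the scatter. The estimated change is a 1.3-fold higher number from compound 3 to compound 4 (0.12 log units; within the scatter). For compound 4 the estimate is 0.09 mg/kg, with an expected range from 0.04 mg/kg to 0.2 mg/kg.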

Compound 4, dose for half-maximal effect: > 0.1 mg/kg
Compound 4: only a limit was reported (the forecaster's own chance of this, stated with the estimate: 30%); middle value at least 1.1-fold (0.04 log units) from the limit.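

In this assay, chloro in place of methylsulfonyl on an aromatic carbon, next to the ring nitrogen, gives an at least 1.4-fold higher number from compound 3 to compound 4 (0.16 log units; that floor lies within the scatter), and the comparison with the other numbered compound gives an at least 1.4-fold higher number from compound 1 to compound 4 (0.16 log units; that floor lies within the scatter). Both floors lie within the scatter, so neither step establishes a real loss. What is new is that this single change, with the methylsulfonyl group at the other place kept, is enough for compound 4 to give a limit and not a number, like compound 2, which carries chloro at both places: the limit of > 0.1 mg/kg in this assay, at which 2 of the 4 values shown sit.

The step between compound 2 and compound 4 cannot be read, since both values are limits. As far as these compounds go, the size of the effect of chloro therefore stays open, as does the outcome with an amine or a methoxy group at this place.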